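This account rests on a few compounds, and the source may have more. Where it says the series, first, only, none or still open, it means among the compounds named here.

Three compounds have numbers in a functional assay on SW1573 cells (Homo sapiens) for antiproliferative activity, read by sulforhodamine B assay, with a stated time of 48 h; on this read-out lower numbers stand for stronger inhibition of growth and higher numbers for weaker inhibition of growth. Compound 1 `C#CC(O/C=C/C(=O)OC)c1ccccc1` gives 31000 nM, compound 3 `Cc1ccc(S(=O)(=O)C#CC(O/C=C/S(=O)(=O)c2ccc(C)cc2)C(C)C)cc1` gives 3200 nM, and compound 2 `CCC(C#CC(=O)OC)O/C=C/C(=O)OC` gives 540 nM. On these numbers compound 2 stands lowest, with compound 3 its nearest neighbour and compound 1 furthest away, both gaps beyond the scatter.

Compound 4 `COC(=O)C#CC(C)O/C=C/C(=O)OC` has not yet been measured in this assay. It differs from compound 2 by hydrogen in place of methyl on a saturated chain carbon, two bonds along the chain from an oxygen on an unsaturated carbon and a triple-bonded carbon. Among the compounds with values here, no pair of measured compounds shows a step of this kind, so the expected step from ethyl to methyl rests on the change alone: a small loss, or none beyond the scatter, is expected, as a 1.5-fold higher number from compound 2 to compound 4 (0.17 log units; within the scatter).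

Compound 4 is therefore expected to give about 800 nM, within a range from 300 nM to 2500 nM.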

Compound 4, concentration for 50% growth inhibition: 1700 nM
The estimate for compound 4 lay 2.1-fold (0.33 log units) below the measured number, within the range that was stated.
By their numbers in this assay, from the lowest: compound 2; then compounds 4 and 3 (each within the scatter of the next); then compound 1.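

In this assay the change from ethyl to methyl on this saturated chain carbon gives a 3.1-fold higher number from compound 2 to compound 4 (0.50 log units; beyond the scatter) and so shows that removing one carbon here costs a modest but real amount of growth inhibition. Within the data shown here, it is the first comparison in this set in which only one place differs, and it shows that this position responds to the length of the chain. No measurement shown here explains the loss. From the compounds shown here alone, whether a longer chain such as propyl would lower the number further remains open, as does the effect of an amine at this position.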